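The source may report more compounds than this note shows. Statements on the series, on what has been measured and on what is new or still open speak of the compounds shown alone.

In a functional assay on HeLa cells (Homo sapiens) for cytotoxicity, read by WST assay, with a stated time of 48 h (on this read-out lower numbers stand for stronger inhibition and higher numbers for weaker inhibition), three compounds have been measured so far. Compound 1 `COc1cccc([C@@H]2OC[C@H]([C@@H](O)c3ccc(OC)c(OC)c3)C[C@H]2C/C=C/c2ccc(OC)c(OC)c2)c1` gives 30100 nM, and compound 2 `COc1ccc(/C=C/C[C@H]2C[C@H]([C@H](O)c3ccc(OC)c(OC)c3)CO[C@@H]2c2ccc(OC)c(OC)c2)cc1OC` gives 34600 nM. Compound 3 `Oc1ccc(/C=C/C[C@H]2C[C@@H]([C@@H](O)c3ccccc3)CO[C@@H]2c2ccccc2)cc1` gives 14400 nM, the lowest of the three numbers; its nearest neighbour is compound 1, and the gap to it, as the gap to compound 2, lies beyond the usual scatter, so compound 3 stands as the strongest inhibitor of the three. For the measured compounds named here, no two of the measured compounds differ in only one place, so no single measured step is available. Compound 4 `O[C@@H](c1ccccc1)[C@H]1CO[C@H](c2ccccc2)[C@@H](C/C=C/C2CCCCC2)C1` has not yet been tested in this assay. It differs from compound 3 in one place: cyclohexyl in place of 4-hydroxyphenyl on a double-bonded chain carbon bound to a double-bonded chain carbon. Going by the values given here, nothing among the measured compounds shows what such an exchange does, since none of them varies on that double-bonded chain carbon. The author therefore expects the step of a 1.0-fold higher number from compound 3 to compound 4 (0.02 log units; within the scatter) to be small, within the scatter, with no clear direction. For compound 4 the estimate in this assay is 15000 nM, with a range from 5000 nM to 45000 nM.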

Compound 4, half-maximal inhibitory concentration: 6440 nM
Estimate against measurement, compound 4: 2.3-fold (0.37 log units) above; the range from low to high includes it.
By their numbers in this assay, from the lowest: compound 4; then compound 3; then compounds 1 and 2 (each within the scatter of the next).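

In this assay, cyclohexyl in place of 4-hydroxyphenyl on a double-bonded chain carbon bound to a double-bonded chain carbon gives a 2.2-fold lower number from compound 3 to compound 4 (0.35 log units; beyond the scatter), a modest step but one that lies beyond the usual scatter. For the compounds shown here, this is the first view of this position, and it shows that, in this pair, a non-aromatic ring of carbon only, with no hydrogen-bond donor or acceptor, goes with stronger inhibition than the 4-hydroxyphenyl ring. Nothing in the data shown explains the step.

The change removes the aromatic ring and the hydroxyl together, so the two remain unseparated; a plain phenyl group at this place would tell them apart. Also open, as far as these compounds go, is how a piperidine ring or a longer open carbon chain would behave here.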